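Acetyl for Phenylsulfonyl on a Shared Core

The source may report more compounds than this note shows. Statements on the series, on what has been measured and on what is new or still open speak of the compounds shown alone.

Compound 1 `CC(=O)Nc1cccc(-c2cnc3[nH]cc(-c4ccncc4)c3c2)c1` gives 9100 nM in a functional assay on MCF7 cells (Homo sapiens) for cytotoxicity, read by MTT assay, with a stated time of 48 h; on this read-out higher numbers stand for weaker inhibition and lower numbers for stronger inhibition. Compound 2 `Nc1cc(NS(=O)(=O)c2ccccc2)cc(-c2cnc3[nH]cc(-c4ccncc4)c3c2)c1` gives 8800 nM in this assay, the lower of the two numbers, yet so close to compound 1 that the two lie within the scatter of each other. Compound 3 `CC(=O)Nc1cc(N)cc(-c2cnc3[nH]cc(-c4ccncc4)c3c2)c1` is not yet measured; it differs from compound 2 by acetyl in place of phenylsulfonyl on a nitrogen on an aromatic ring. Since compound 1 at 9100 nM and compound 2 at 8800 nM sit together, compound 3 is expected to show a step of a 1.0-fold higher number from compound 2 to compound 3 (0.01 log units; within the scatter) in this assay, none beyond the scatter. Compound 3 is estimated at 9000 nM, between 4000 nM and 20000 nM.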

Compound 3, half-maximal inhibitory concentration: > 30000 nM
Compound 3: a limit, no number; the forecaster's own chance of this, stated with the estimate: 5%; at least 3.3-fold (0.52 log units) between middle value and limit.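

In this assay compound 3 reads > 30000 nM, which is a limit of the assay and not a number. On a nitrogen on an aromatic ring, acetyl in place of phenylsulfonyl gives an at least 3.4-fold higher number from compound 2 to compound 3 (0.53 log units; beyond the scatter), so the group held there counts, which the two earlier values, within the scatter of each other, could not show. Amino in place of hydrogen on an aromatic carbon gives an at least 3.2-fold higher number from compound 1 to compound 3 (0.51 log units; beyond the scatter), so that change counts as well. On these data alone, the true size of both steps stays open. So does whether benzoyl or methanesulfonyl on the same nitrogen would read like phenylsulfonyl or like acetyl.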